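Pyrazinyl for pyridinyl: a ring swap on the piperazine

The compounds below may be only part of what the source reports. "The series", "measured", "known", "first", "only" and "open" are said of these compounds alone.

Of the compounds shown here, three with a shared core have been tested in a functional assay on A-375 cells (Homo sapiens) for antiproliferative activity, read by CCK-8 assay, with a stated time of 72 h, tested at 2 uM; a lower number here means a weaker effect, a higher number a stronger effect of the compound at the concentration tested. Compound 1 `Nc1ccccc1NC(=O)c1ccc(CSC(=S)N2CCc3cc([N+](=O)[O-])ccc32)cc1` gives 16.9%. Compound 2 `CC1CCN(C(=S)SCc2ccc(C(=O)Nc3ccccc3N)cc2)CC1` gives 32.7% in this assay. Compound 3 `Nc1ccccc1NC(=O)c1ccc(CSC(=S)N2CCN(c3ccncc3)CC2)cc1` gives 85.7% in this assay, the highest of the three numbers; its gap to compound 2 and its larger gap to compound 1 both lie beyond the usual scatter, so compound 3 stands clearly above the other two. Compound 4 `Nc1ccccc1NC(=O)c1ccc(CSC(=S)N2CCN(c3cnccn3)CC2)cc1` differs from compound 3 in a single place: pyrazin-2-yl in place of pyridin-4-yl on an amine nitrogen in a ring. Among the compounds with values here, no step between measured compounds covers this exact change, and the other two compounds carry quite different groups at this place, so the size of the change is uncertain. Because compound 3 shows 85.7%, a closely related aromatic ring in the same place is expected to keep much of that effect, with some room for loss. For compound 4 the expected step is a number 13.7 percentage points lower from compound 3 to compound 4 (beyond the scatter), a modest decline that could still fall within the scatter. Compound 4 is estimated at 72%, within a range from 45% to 90%.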

Compound 4, a percentage reported as inhibition, at one concentration (the size of the read-out at that concentration, not a potency): 29.1%
Beside the measured number, compound 4's estimate is 42.9 percentage points above it; measured number outside the range, below it.
By their numbers in this assay, from the lowest: compound 1; then compounds 4 and 2 (each within the scatter of the next); then compound 3.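

Placing pyrazin-2-yl in place of pyridin-4-yl on this amine nitrogen in a ring gives a number 56.6 percentage points lower from compound 3 to compound 4 (beyond the scatter) in this assay, so a large change follows from swapping one six-membered aromatic ring for another with the same count of heavy atoms. The position is therefore sensitive to which aromatic ring it carries, and the high read-out of compound 3 does not extend to every close relative of its ring. No measurement shown here explains this loss.

On these data alone, it remains open whether the loss comes from the added ring nitrogen or from the different point of attachment. Pyridin-2-yl, pyridin-3-yl or a plain phenyl ring at this place, each compared with compound 3, could help separate these possibilities.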